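The source may report more compounds than this note shows. Statements on the series, on what has been measured and on what is new or still open speak of the compounds shown alone.

compound 1 `CC#C[C@@H](Cc1nnn[nH]1)c1ccc(OCc2ccc3scc(-c4cc(OCCOC)ccc4C)c3c2)cc1`: 0.867 h
compound 2 `CC#C[C@@H](Cc1nnn[nH]1)c1ccc(OCc2cc(Cl)c3scc(-c4ccccc4C)c3c2)cc1`: 0.217 h
compound 3 `CC#C[C@@H](Cc1nnn[nH]1)c1ccc(OCc2ccc3sc(C)c(-c4ccc(OCCOC)cc4C)c3c2)cc1`: 1.48 h

These three compounds were tested in an ADME assay on microsomes from liver (Homo sapiens) for metabolic stability; on this read-out lower numbers stand for a shorter-lived compound and higher numbers for a longer-lived compound. Compound 3, at 1.48 h, lies within the usual scatter of compound 1 at 0.867 h, so the two cannot be told apart. Compound 2, at 0.217 h, lies lower than compound 3 by more than the scatter.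

The next compound is compound 4 `CC#C[C@@H](Cc1nnn[nH]1)c1ccc(OCc2ccc3sc(F)c(-c4ccc(OCCOC)cc4C)c3c2)cc1`, which differs from compound 3 in one place: fluoro in place of methyl on an aromatic carbon. In short, the methyl of compound 3 is swapped for fluoro, on an aromatic carbon of a five-membered aromatic ring with 1 sulfur, next to the ring sulfur.

Among the compounds with values here, no two measured compounds differ in only one place, so the data give no direct measure of this swap. Compound 1 carries no methyl on that carbon, but it also differs elsewhere, so it offers only a loose guide. With compound 1 at 0.867 h and compound 3 at 1.48 h, a value in that neighbourhood seems the most reasonable expectation in this assay. The expected change is a 1.2-fold lower number from compound 3 to compound 4 (0.09 log units; within the scatter), a small downward step that is not expected to go beyond the scatter. For compound 4 the estimated half-life is 1.2 h, with an expected range from 0.6 h to 2.4 h.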

Compound 4, half-life: 1.95 h
For compound 4 the middle estimate is 1.6-fold (0.21 log units) below the measured one; the range from low to high includes it.
By their numbers in this assay, from the lowest: compound 2; then compounds 1, 3 and 4 (each within the scatter of the next, the first and the last beyond it).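

In this assay, the swap of methyl for fluoro on this aromatic carbon, next to the ring sulfur, gives a 1.3-fold higher number from compound 3 to compound 4 (0.12 log units; within the scatter). Within the data shown here, this is the first pair that differs in one place only, and it shows that the two groups cannot be told apart on this read-out: with the 4-(2-methoxyethoxy)-2-methylphenyl group on the neighbouring ring atom, this carbon carries either methyl or fluoro with no readable shift in half-life. No measurement shown here explains this result.

The compounds shown leave open how this carbon responds to other groups, such as chloro, an amine, a carboxylic acid or a longer chain like ethyl, and a one-place comparison with plain hydrogen on this carbon is also missing, as compound 1 differs from compound 3 elsewhere too. As far as these compounds go, it also remains open whether the same swap would stay as small on a different core, for instance one with another group in place of the 4-(2-methoxyethoxy)-2-methylphenyl group, as this single pair speaks for one background only.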